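The compounds below may be only part of what the source reports. "The series", "measured", "known", "first", "only" and "open" are said of these compounds alone.

Measured so far in a functional assay on HepG2 cells (Homo sapiens) for inhibition, read by MTT assay, with a stated time of 72 h; on this read-out higher numbers stand for weaker inhibition and lower numbers for stronger inhibition:
compound 1 `Cc1nc(N(C)C(=O)NC(=O)c2c(F)cccc2F)sc1C(=O)N/N=C/c1cccc(C(F)(F)F)c1` — 31.6 ug/mL
compound 2 `Cc1nc(N(C)C(=O)NC(=O)c2c(F)cccc2F)sc1C(=O)N/N=C/c1ccc(F)cc1` — a limit, > 100 ug/mL
compound 3 `Cc1nc(N(C)C(=O)NC(=O)c2c(F)cccc2F)sc1C(=O)N/N=C/c1ccccc1C(F)(F)F` — 1.11 ug/mL

Compound 3 stands at the lowest of the two numbers given; the nearest number is separated from it by the step of a 28-fold lower number from compound 1 to compound 3 (1.45 log units; beyond the scatter). Compound 2 gives no number at all in this assay but only a limit, (the limit of > 100 ug/mL in this assay, at which 1 of the 3 values shown sits).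

Compound 4 `Cc1nc(N(C)C(=O)NC(=O)c2c(F)cccc2F)sc1C(=O)N/N=C/c1ccc(C(F)(F)F)cc1` is the next case, and its difference from compound 3 is 4-(trifluoromethyl)phenyl in place of 2-(trifluoromethyl)phenyl on a carbon with a double bond to nitrogen. Among the measured compounds shown here, two measured steps bear on this change, both describing what happens when the 2-(trifluoromethyl)phenyl of compound 3 is exchanged for another aryl group on the same carbon. The first is a 28-fold lower number from compound 1 to compound 3 (1.45 log units; beyond the scatter), read in reverse: moving the trifluoromethyl from the 2-position to the 3-position costs a large amount. The second is an at least 90-fold lower number from compound 2 to compound 3 (1.95 log units; beyond the scatter), again read in reverse: a 4-fluorophenyl in that place loses even more, so far that only a limit is reached. Both steps point the same way, and compound 4 carries its trifluoromethyl at the 4-position, so a large rise in the number is expected, a 36-fold higher number from compound 3 to compound 4 (1.56 log units; beyond the scatter). Compound 4 is therefore estimated at 40 ug/mL in this assay, within a range of 8 ug/mL to 150 ug/mL, with a fair chance that only a limit is recorded.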

Compound 4, half-maximal inhibitory concentration: > 100 ug/mL
Compound 4: no number, only a limit (the forecaster's own chance of this, stated with the estimate: 35%); at least 2.5-fold (0.39 log units) between middle value and limit.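

Of the three trifluoromethyl isomers, only the 2-(trifluoromethyl)phenyl compound gives a low number in this assay: exchanging it for 4-(trifluoromethyl)phenyl on the carbon with a double bond to nitrogen gives an at least 90-fold higher number from compound 3 to compound 4 (1.95 log units; beyond the scatter), although the atoms stay the same and are only joined differently. The 3-(trifluoromethyl)phenyl and 4-(trifluoromethyl)phenyl compounds also separate, since the second in place of the first gives an at least 3.1-fold higher number from compound 1 to compound 4 (0.50 log units; beyond the scatter), so the outcome at this place depends on how the trifluoromethyl-bearing phenyl is joined and not only on which atoms it holds. Compound 4 yields only a limit, as compound 2 does, so the step from fluoro to trifluoromethyl on the aromatic carbon cannot be read: the limit of > 100 ug/mL in this assay, at which 2 of the 4 values shown sit.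

The compounds shown leave open whether a 2-chlorophenyl or a 2-methoxyphenyl in place of 2-(trifluoromethyl)phenyl would keep a number close to that of compound 3, at 1.11 ug/mL. They also leave open how far compound 2 and compound 4 lie from each other beyond their shared limit.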